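Solubility notes on the shared core series

The source may hold more compounds than are shown below. What is called first, only, known or untested is meant among the compounds shown, and "the series" means these compounds.

Compound 1 `CC(C)(C)c1cc(NC(=O)[C@@H]2CCCCN2C2CC2)no1`: 38 ug/mL
Compound 2 `CC(C)(C)c1cc(NC(=O)[C@@H]2CCCCN2C(=O)c2ccc(Cl)cc2)no1`: a limit of the assay, < 0.1 ug/mL
Compound 3 `CC(C)(C)c1cc(NC(=O)[C@@H]2CCCCN2C(=O)C2CCCCC2)no1`: 6.4 ug/mL

In a physicochemical assay for solubility, read by HPLC, at pH 6.8 (on this read-out lower numbers stand for lower solubility and higher numbers for higher solubility), compound 1 stands highest of the two numbers reported; the nearest number is a 5.9-fold lower number from compound 1 to compound 3 (0.77 log units; beyond the scatter). Compound 2 gives only a limit of the assay, (the limit of < 0.1 ug/mL in this assay, at which 1 of the 3 values shown sits). Between the two acyl groups the step is an at least 64-fold higher number from compound 2 to compound 3 (1.80 log units; beyond the scatter).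

Compound 4 `CC(C)(C)c1cc(NC(=O)[C@@H]2CCCCN2C(=O)N2CC[S+]([O-])CC2)no1` is not yet measured. It differs from compound 1 in that (a group of 9 heavy atoms (5 carbon, 1 nitrogen, 2 oxygen, 1 sulfur; one six-membered non-aromatic ring with 2 hetero atoms) in place of a group of 3 heavy atoms (3 carbon; one three-membered non-aromatic ring of carbon only), on an amine nitrogen in a ring). Both measured steps from compound 1 put a carbonyl-bearing group on that ring nitrogen in place of cyclopropyl and lowered the number: an at least 380-fold lower number from compound 1 to compound 2 (2.57 log units; beyond the scatter) and a 5.9-fold lower number from compound 1 to compound 3 (0.77 log units; beyond the scatter). The entering group of compound 4 likewise carries a carbonyl on that nitrogen, so a lower number is expected for compound 4, with a step of a 2.5-fold lower number from compound 1 to compound 4 (0.40 log units; beyond the scatter), nearer the cyclohexylcarbonyl case than the 4-chlorophenylcarbonyl one. Compound 4 is therefore estimated at 15 ug/mL, expected to fall between 3 ug/mL and 60 ug/mL.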

Compound 4, solubility: 68 ug/mL
Beside the measured number, compound 4's estimate is 4.5-fold (0.66 log units) below it; the whole stated range lies below it.
By their numbers in this assay, from the lowest: compound 3; then compounds 1 and 4 (each within the scatter of the next). At a limit, below all of these: compound 2.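

On the amine nitrogen in a ring, a carbonyl-bearing group need not go with a lower number: in this assay the step is a 1.8-fold higher number from compound 1 to compound 4 (0.25 log units; within the scatter), which leaves compounds 1 and 4 unseparated, whereas compounds 2 and 3 both stand lower than compound 1. With the carbonyl kept, the number moves widely with the group on the carbonyl carbon: the six-membered non-aromatic ring with 2 hetero atoms in place of cyclohexyl gives an 11-fold higher number from compound 3 to compound 4 (1.03 log units; beyond the scatter). In place of 4-chlorophenyl the same ring gives an at least 680-fold higher number from compound 2 to compound 4 (2.83 log units; beyond the scatter), and compound 2 stands only at a limit of the assay: the limit of < 0.1 ug/mL in this assay, at which 1 of the 4 values shown sits.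

Open, going by these compounds, is which part of the entering ring goes with the gain over cyclohexyl; a piperidine or morpholine on the same carbonyl would separate the ring nitrogen from the sulfur oxide. Also open, on these data alone, is where a simple alkyl chain bearing an amine or a carboxylic acid on the ring nitrogen would stand against compound 1.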